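The compounds below may be only part of what the source reports. "The series", "measured", "known", "first", "only" and "open" are said of these compounds alone.

Compound 1, `CCCCCCCCCCNC(=O)CCCSC[C@H](NC(=O)OCc1ccccc1)C(=O)Nc1ccccc1`: in an assay for inhibition of NAD-dependent protein deacylase sirtuin-6 (Homo sapiens), read by HPLC, with stated times of 15 min and 1 h, tested at 333 uM (on this read-out higher numbers stand for more inhibition at the one concentration tested (going by the name of the read-out) and lower numbers for less inhibition), compound 1 gives 28%.
Compound 2, `CCCCCCCCCCCCCNC(=O)CCCSC[C@H](NC(=O)OCc1ccccc1)C(=O)Nc1ccccc1`: in this assay compound 2 gives 31%.
Compound 3, `CCNC(=O)CCCSC[C@H](NC(=O)OCc1ccccc1)C(=O)Nc1ccccc1`: in this assay compound 3 gives 15%.

Compound 3 stands lowest of the three numbers in this assay. Its nearest neighbour is compound 1, separated by the step of a number 13 percentage points lower from compound 1 to compound 3 (beyond the scatter); the furthest is compound 2, separated by a number 16 percentage points lower from compound 2 to compound 3 (beyond the scatter). Compound 1 and compound 2 themselves differ only by a number 3 percentage points higher from compound 1 to compound 2 (within the scatter), so the two longer chains are not distinguished by this read-out.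

Compound 4, `CCCCCCCCNC(=O)CCCSC[C@H](NC(=O)OCc1ccccc1)C(=O)Nc1ccccc1`, has not yet been measured in this assay. Relative to compound 3 the change is hexyl in place of hydrogen on a saturated chain carbon, two bonds along the chain from an amide-type nitrogen. The two steps that bear on it are those from the longer chains down to compound 3: a number 13 percentage points lower from compound 1 to compound 3 (beyond the scatter) and a number 16 percentage points lower from compound 2 to compound 3 (beyond the scatter), both modest and both beyond the scatter, and both running the same way when a chain of this kind is removed. Going the other way, from hydrogen to hexyl, a rise of comparable size is therefore expected, with hexyl lying between the ethyl of compound 3 and the decyl of compound 1. The step from compound 3 to compound 4 is estimated at a number 10 percentage points higher from compound 3 to compound 4 (within the scatter). For compound 4 the value in this assay is estimated at 25%, with a range from 15% to 35%.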

Compound 4, a percentage reported as inhibition, at one concentration (the size of the read-out at that concentration, not a potency): "not active" (no number reported)
For compound 4 the study gives words and no number; no gap can be computed for the estimate.
By their numbers in this assay, from the lowest: compound 3; then compounds 1 and 2 (each within the scatter of the next).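

In this assay, for the compounds shown here, compound 4 is reported in words as not active, without a number, so no step linking it to compound 1, compound 2 or compound 3 can be read. No measured evidence bears on this result. The compounds shown leave open how that verdict relates to the numbers of the other three and whether chain length relates consistently to this read-out.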